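This account rests on a few compounds, and the source may have more. Where it says the series, first, only, none or still open, it means among the compounds named here.

Three compounds sharing one core have numbers in a functional assay on MDA-MB-231 cells (Homo sapiens) for cytotoxicity, read by sulforhodamine B assay, with a stated time of 72 h; a higher number here means a weaker inhibitor of growth, a lower number a stronger inhibitor of growth. Compound 1 `O=C(Nc1ccc(C(F)(F)F)cc1)C1CCc2ccccc2N1` gives 24200 nM, compound 2 `O=C(Nc1ccccc1C(F)(F)F)C1CCc2ccccc2N1` gives 45500 nM, and compound 3 `O=C(Nc1ccccc1O)C1CCc2ccccc2N1` gives 5260 nM. Compound 3 is the lowest of the three, and its gaps to the other two lie beyond the scatter. Compound 4 `O=C(Nc1ccccc1)C1CCc2ccccc2N1` is next and differs from compound 3 as follows: hydrogen in place of hydroxy on an aromatic carbon. This places hydrogen in place of hydroxy on an aromatic carbon, ortho to a large group.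

For the measured compounds named here, only one measured step bears on this change: an 8.7-fold lower number from compound 2 to compound 3 (0.94 log units; beyond the scatter), a modest step beyond the scatter, with hydroxy in place of trifluoromethyl on an aromatic carbon. Going by the values given here, that step starts from trifluoromethyl, and no measured compound has hydrogen at this carbon, so it gives direction only loosely. A move to a higher number in this assay is expected, smaller than the measured step. The estimated change is a 2.9-fold higher number from compound 3 to compound 4 (0.46 log units; beyond the scatter). For compound 4 the estimate is 15000 nM, with an expected range of 6000 nM to 40000 nM.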

Compound 4, concentration for 50% growth inhibition: 108000 nM
Compound 4: the middle estimate sits 7.2-fold (0.86 log units) below what was measured; measured number outside the range, above it.
By their numbers in this assay, from the lowest: compound 3; then compounds 1 and 2 (each within the scatter of the next); then compound 4.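

In this assay, for the compounds shown here, compound 4 gives the first direct reading of hydroxy against hydrogen on this carbon, and the step is large: a 21-fold higher number from compound 3 to compound 4 (1.31 log units; beyond the scatter). Hydrogen is therefore not a neutral reference point here, since both trifluoromethyl compounds also lie below compound 4, with a 2.4-fold higher number from compound 2 to compound 4 (0.38 log units; beyond the scatter) and a 4.5-fold higher number from compound 1 to compound 4 (0.65 log units; beyond the scatter), both modest. Among the four compounds, each of those carrying a group on this aromatic ring has a lower number than compound 4, with none going against this, and hydroxy in compound 3 gives by far the largest step from hydrogen.

Nothing available accounts for the size of the hydroxy step. Open, going by these compounds, is whether an amine or a methoxy group on the same carbon would stay near compound 3 or return towards compound 4.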